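Exchanging One Six-Membered Heteroaryl Ring for Another

The source may hold more compounds than are shown below. What is called first, only, known or untested is meant among the compounds shown, and "the series" means these compounds.

Of the compounds shown here, two have been measured so far in a functional assay for activation of Alpha-1B adrenergic receptor (Homo sapiens), read by calcium flux; on this read-out higher numbers stand for an effect only at larger amounts of compound and lower numbers for an effect already at smaller amounts. Compound 2 `c1ccc(-c2cnccn2)c(NCC2=NCCN2)c1` gives 339 nM, while compound 1 `Cc1nc(-c2ccccc2NCC2=NCCN2)no1` gives 676 nM; the step of a 2.0-fold lower number from compound 1 to compound 2 (0.30 log units; within the scatter) means the two cannot be ranked against each other. Compound 3 `c1cnc(-c2ccccc2NCC2=NCCN2)nc1` differs from compound 2 by pyrimidin-2-yl in place of pyrazin-2-yl on an aromatic carbon. Among the measured compounds shown here, the only measured step also exchanges one aromatic ring for another and stays within the scatter, and no measurement exchanges these two rings in particular, so no change beyond the scatter is expected in this assay. Compound 3 is therefore expected to give 350 nM, with a range from 120 nM to 1000 nM. The expected step is a 1.0-fold higher number from compound 2 to compound 3 (0.01 log units; within the scatter).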

Compound 3, half-maximal effective concentration: 77.6 nM
Beside the measured number, compound 3's estimate is 4.5-fold (0.65 log units) above it; the whole stated range lies above it.
By their numbers in this assay, from the lowest: compound 3; then compounds 2 and 1 (each within the scatter of the next).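

In this assay pyrimidin-2-yl gives a 4.4-fold lower number from compound 2 to compound 3 (0.64 log units; beyond the scatter) and, against the 5-methyl-1,2,4-oxadiazol-3-yl group, an 8.7-fold lower number from compound 1 to compound 3 (0.94 log units; beyond the scatter). The first of these steps shows that at this position two rings with the same atoms, joined differently, can be told apart beyond the scatter, which the earlier step could not show. Nothing at hand explains the difference. Open, from the compounds shown here alone, is whether a pyridin-2-yl ring, with a single ring nitrogen, or a plain phenyl ring would give a lower or higher number here.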